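A few compounds are considered here, and "the series" means these few. Any claim that something is new, unique, unknown or untested is made for them only; others in the source may bear on it.

Compound 1, `CN(C)C(=O)C[C@@H]1CN[C@H](C(=O)N2CCC[C@H]2C#N)C1`: 66%
Compound 2, `CCCNC(=O)[C@@H]1CN[C@H](C(=O)N2CCC[C@H]2C#N)C1`: 59%

In an assay on the whole organism (plasma, strain Sprague-Dawley) for inhibition of Dipeptidyl peptidase 4 (Rattus norvegicus), with a stated time of 6 h, at a dose of 1 mg/kg by the oral route (a lower number here means less inhibition, a higher number more inhibition at the dose given (going by the name of the read-out)), compound 1 gives 66% and compound 2 gives 59%. Going by the values given here, the one step measured so far, a number 7 percentage points lower from compound 1 to compound 2 (within the scatter), places the two numbers within the usual scatter of each other, so neither stands apart. Compound 3, `CCNC(=O)[C@@H]1CN[C@H](C(=O)N2CCC[C@H]2C#N)C1`, carries a shorter chain: hydrogen in place of methyl on a saturated chain carbon, two bonds along the chain from an amide-type nitrogen. Among the compounds with values here, no measured step changes this chain, so the only guide is the small size of the single step seen. The step of no change at the digits printed from compound 2 to compound 3 (within the scatter) is therefore expected to stay within the scatter. Compound 3 is estimated to give about 59%, between 45% and 72%.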

Compound 3, a percentage reported as inhibition, in the whole organism at one dose (the size of the read-out at that dose, not a potency): 60%
Beside the measured number, compound 3's estimate is 1 percentage points below it; measured number inside the range.
By their numbers in this assay, from the lowest: compounds 2, 3 and 1 (each within the scatter of the next).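

In this assay, cutting the chain from propyl to ethyl gives a small step (a number 1 percentage points higher from compound 2 to compound 3 (within the scatter)), so this shortening does not move the read-out beyond the scatter. Ethylcarbamoyl in place of (dimethylcarbamoyl)methyl on the saturated ring carbon also stays within the scatter (a number 6 percentage points lower from compound 1 to compound 3 (within the scatter)), as propylcarbamoyl did. Nothing available offers an explanation for these small steps. Open, as far as these compounds go, is whether a methyl group, a butyl chain or a carboxylic acid in place of the ethyl would keep the read-out in this range.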